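Methyl to nitro on the pendant phenyl: expectation

A few compounds are considered here, and "the series" means these few. Any claim that something is new, unique, unknown or untested is made for them only; others in the source may bear on it.

Of the compounds shown here, two have been measured in a functional assay on MCF7 cells (Homo sapiens) for inhibition, read by sulforhodamine B assay, with a stated time of 72 h; on this read-out lower numbers stand for stronger inhibition and higher numbers for weaker inhibition. Compound 1 `COc1ccc(C2=Nn3c(nnc3C(C)c3ccc(-c4ccccc4)c(F)c3)SC2)cc1` gives 2600 nM in this assay. Compound 2 `Cc1ccc(C2=Nn3c(nnc3C(C)c3ccc(-c4ccccc4)c(F)c3)SC2)cc1` gives 5000 nM in this assay. Within the data shown here, the one step between them, a 1.9-fold higher number from compound 1 to compound 2 (0.28 log units; within the scatter), is within the scatter, so the two numbers cannot be ordered. Among the measured compounds shown here, compound 2 stands at the higher of the two numbers, with compound 1 as its only neighbour.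

Compound 3 `CC(c1ccc(-c2ccccc2)c(F)c1)c1nnc2n1N=C(c1ccc([N+](=O)[O-])cc1)CS2` is not yet measured. It differs from compound 2 by nitro in place of methyl on an aromatic carbon, the same difference read one bond further out being 4-methylphenyl to 4-nitrophenyl.

For the measured compounds named here, no measured step involves a nitro group; the only step on this aromatic carbon, methoxy to methyl, stayed within the scatter. Going by the values given here, that step bears on the present one only in showing that a change at this carbon gave no movement beyond the scatter, and no step of the present kind is available. Therefore no step beyond the scatter is expected in this assay for compound 3, with the direction undetermined, and compound 3 is estimated at 4000 nM, within 1300 nM to 12000 nM. The estimated step of a 1.3-fold lower number from compound 2 to compound 3 (0.10 log units; within the scatter) is expected to lie inside the scatter.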

Compound 3, half-maximal inhibitory concentration: 7800 nM
The estimate for compound 3 lay 2.0-fold (0.29 log units) below the measured number; the measured number falls inside the stated range.
By their numbers in this assay, from the lowest: compounds 1, 2 and 3 (each within the scatter of the next, the first and the last beyond it).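

In this assay, 4-methylphenyl to 4-nitrophenyl gives a 1.6-fold higher number from compound 2 to compound 3 (0.19 log units; within the scatter), so this change cannot be told apart from no movement at this aromatic carbon. Nitro in place of methoxy on the same carbon gives a 3.0-fold higher number from compound 1 to compound 3 (0.48 log units; beyond the scatter), a modest step but the first at this position to lie beyond the scatter, which shows that the number here can respond to the group carried at this carbon, even though neither step involving methyl can be read as a change. Nothing available gives a reason for this step.

As far as these compounds go, with only methoxy, methyl and nitro compared at this carbon, it remains open whether an amine, a carboxylic acid or a longer chain such as propoxy would move the number further in either direction, or would bring it below that of compound 1. From the compounds shown here alone, all three compounds share the rest of the structure and a single read-out, so it is also open whether the gap between compound 1 and compound 3 would persist with a different core or in a different assay.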